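Ethylamino in place of piperidin-1-yl

The compounds below may be only part of what the source reports. "The series", "measured", "known", "first", "only" and "open" are said of these compounds alone.

Compound 1 `CC(C)=CCc1cc(C(=O)Nc2cc3ccc(OCC4CCCN(C)C4)c(C)c3oc2=O)ccc1O`: 2640 nM
Compound 2 `CC(C)=CCc1cc(C(=O)Nc2cc3ccc(OCCCN4CCCCC4)c(C)c3oc2=O)ccc1O`: > 50000 nM (a limit)
Compound 3 `CCNCCCOc1ccc2cc(NC(=O)c3ccc(O)c(CC=C(C)C)c3)c(=O)oc2c1C`: not yet measured

In a functional assay on MCF7 cells (Homo sapiens) for antiproliferative activity (a higher number here means a weaker inhibitor, a lower number a stronger inhibitor), compound 2 stands at a limit of the measurement (> 50000 nM), not at a number. In compound 3, ethylamino takes the place of piperidin-1-yl (ethylamino in place of piperidin-1-yl on a saturated chain carbon, three bonds along the chain from an oxygen on an aromatic ring) on a saturated chain carbon, three bonds along the chain from an oxygen on an aromatic ring. Among the measured compounds shown here, only one measured step bears on this: an at least 18-fold higher number from compound 1 to compound 2 (1.27 log units; beyond the scatter) is large and lies in the same side chain, though it is a different change. It shows that this side chain can move the number a long way, so a clear shift in this assay toward a lower number is expected. The expected change is an at least 4.1-fold lower number from compound 2 to compound 3 (0.61 log units; beyond the scatter), with a real chance that the result stays at the limit. For compound 3 the estimate is 12000 nM, with an expected range from 2000 nM to 50000 nM.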

Compound 3, half-maximal inhibitory concentration: 980 nM
Compound 3: the middle estimate sits 12-fold (1.09 log units) above what was measured; measured number outside the range, below it.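

In this assay, ethylamino at the end of the chain separates sharply from piperidin-1-yl at the same place, with an at least 51-fold lower number from compound 2 to compound 3 (1.70 log units; beyond the scatter). Compound 2 stands at a limit and not at a number, so the true size of that step is unknown and it can be read only as a bound: the limit of > 50000 nM in this assay, at which 1 of the 3 values shown sits. Set against the 1-methylpiperidin-3-yl side chain, the open 2-(ethylamino)ethyl group gives a 2.7-fold lower number from compound 1 to compound 3 (0.43 log units; beyond the scatter), so among these compounds a ring in the side chain is not needed for activity at this place.

The compounds shown leave open whether the difference follows the loss of the ring or the hydrogen-bond donor that ethylamino brings, a question that dimethylamino on the same chain would bear on. Also open, on these data alone, is how larger open amines, such as propylamino, would read here.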